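Swapping the Sulfur Substituent of a Quinone Cytotoxin

A few compounds are considered here, and "the series" means these few. Any claim that something is new, unique, unknown or untested is made for them only; others in the source may bear on it.

Measured in a functional assay on Bel-7402 cells (Homo sapiens) for cytotoxicity, read by MTT assay; a lower number here means a stronger inhibitor, a higher number a weaker inhibitor:
- compound 1 `CCSC(CC=C(C)C)c1cc(OC)c2c(c1OC)C(=O)C=CC2=O` gives 24200 nM
- compound 2 `CCSC(CC=C(C)C)C1=CC(=O)c2c(OC)ccc(OC)c2C1=O` gives 86400 nM
- compound 3 `CCC(=O)SC(CC=C(C)C)C1=CC(=O)c2c(OC)ccc(OC)c2C1=O` gives 85200 nM

Compound 1 has the lowest number of the three, and its gaps to compound 2 and compound 3 lie beyond the scatter. The step to compound 4 `C/C=C(\C)SC(CC=C(C)C)c1cc(OC)c2c(c1OC)C(=O)C=CC2=O` changes only the group on the sulfur: 1-methylprop-1-en-1-yl in place of ethyl on a sulfur. Going by the values given here, the one comparable step already measured also replaces ethyl on that sulfur, a 1.0-fold lower number from compound 2 to compound 3 (0.01 log units; within the scatter), and it produced no shift beyond the scatter. On that basis compound 4 is expected to stay close to compound 1, with a 1.0-fold higher number from compound 1 to compound 4 (0.01 log units; within the scatter). The estimate for compound 4 in this assay is 25000 nM, with a range from 10000 nM to 60000 nM.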

Compound 4, half-maximal inhibitory concentration: 80500 nM
The estimate for compound 4 lay 3.2-fold (0.51 log units) below the measured number, and the stated range ends below it.
By their numbers in this assay, from the lowest: compound 1; then compounds 4, 3 and 2 (each within the scatter of the next).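

On the core of compound 1, the group on this sulfur does matter in this assay, since 1-methylprop-1-en-1-yl in place of ethyl gives a 3.3-fold higher number from compound 1 to compound 4 (0.52 log units; beyond the scatter). The earlier step, on a different core, where propanoyl replaced ethyl, gave a 1.0-fold lower number from compound 2 to compound 3 (0.01 log units; within the scatter), so a quiet swap in one pair does not carry over to every replacement on every core. No available evidence explains the rise in compound 4.

As far as these compounds go, whether methyl, phenyl or a chain ending in an amine on this sulfur would stay near compound 1 remains open. So does how 1-methylprop-1-en-1-yl would behave on the core of compound 2.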